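Formyl gives way to 2-methylprop-1-en-1-yl

The source may report more compounds than this note shows. Statements on the series, on what has been measured and on what is new or still open speak of the compounds shown alone.

In a functional assay on MCF7 cells (Homo sapiens) for cytotoxicity, in the presence of a further agent that is not named here (a higher number here means that more compound is needed for the effect, a lower number that less compound is needed), compound 1 `CCCCCCCO[C@@H]1[C@@H](OCc2ccccc2)[C@@H](OCc2ccccc2)O[C@H](CO)[C@H]1OCc1ccc(OC)cc1` gives 3 ug/mL and compound 2 `CCCCCCCO[C@@H]1[C@@H](OCc2ccccc2)[C@@H](OCc2ccccc2)O[C@H](C=O)[C@H]1OCc1ccc(OC)cc1` gives 4 ug/mL so these two cannot be told apart. Going by the values given here, the one measured step of a 1.3-fold higher number from compound 1 to compound 2 (0.12 log units; within the scatter) lies within the scatter and exchanged hydroxymethyl for formyl on the same saturated ring carbon. Among the compounds with values here, compound 3 `CCCCCCCO[C@@H]1[C@@H](OCc2ccccc2)[C@@H](OCc2ccccc2)O[C@H](C=C(C)C)[C@H]1OCc1ccc(OC)cc1` has 2-methylprop-1-en-1-yl in place of formyl on a saturated ring carbon and no measured compound carries this group, so the earlier step is only a loose guide. The step expected in this assay is no change at the digits printed from compound 2 to compound 3 (within the scatter) and none beyond the scatter. Compound 3 is estimated at 4 ug/mL within an expected range of 1.5 ug/mL to 10 ug/mL for now.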

Compound 3, half-maximal effective concentration: > 20 ug/mL
Compound 3: no number, only a limit; the forecaster's own chance of this, stated with the estimate: 10%; middle value at least 5.0-fold (0.69 log units) away from the limit.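

Hydroxymethyl and formyl on this saturated ring carbon could not be told apart, so the earlier compounds gave no sign that the position matters. The change to 2-methylprop-1-en-1-yl gives an at least 5.0-fold higher number from compound 2 to compound 3 (0.69 log units; beyond the scatter) and, measured against hydroxymethyl, an at least 6.6-fold higher number from compound 1 to compound 3 (0.82 log units; beyond the scatter) in this assay, so what sits here can shift the read-out beyond the scatter. The value of compound 3 is a limit and not a number: the limit of > 20 ug/mL in this assay, at which 1 of the 3 values shown sits.

On these data alone, how far compound 3 lies past that limit stays open, so the true size of both steps is unknown. Also open, as far as these compounds go, is how an amine or a carboxylic acid on this same carbon would read.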